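A few compounds are considered here, and "the series" means these few. Any claim that something is new, unique, unknown or untested is made for them only; others in the source may bear on it.

Measured so far in an ADME assay on HepG2 cells (Homo sapiens) for cytotoxicity, with a stated time of 72 h; a lower number here means that less compound is needed, a higher number that more compound is needed for the effect:
compound 1 `Cc1cc(NC(=O)Nc2ccc(C)c(Cl)c2)c2ccccc2n1` gives > 25000 nM, which is a limit of the assay rather than a number.
compound 2 `Cc1cc(NC(=O)Nc2ncccc2C)c2ccccc2n1` gives > 25000 nM, again a limit of the assay.
compound 3 `Cc1ccc(NC(=O)Nc2cc(C)nc3ccccc23)cc1` gives > 25000 nM, also a limit of the assay.

Compound 3 stands at the limit of > 25000 nM in this assay, at which 3 of the 3 values shown sit. Going by the values given here, every value so far is a limit. The two steps leading to compound 3, a step that the two limits leave unreadable from compound 1 to compound 3 and a step that the two limits leave unreadable from compound 2 to compound 3, have no readable size, and neither touches the group that changes next. Compound 4 `CC(=O)c1ccc(NC(=O)Nc2cc(C)nc3ccccc23)cc1` carries acetyl in place of methyl on an aromatic carbon. Among the compounds with values here, no measured step bears on this change, so no shift beyond the scatter is expected in this assay. Compound 4 is expected at 30000 nM, with a range from 10000 nM to 100000 nM, which corresponds to an estimated step that the limit leaves unreadable from compound 3 to compound 4.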

Compound 4, half-maximal effective concentration: 19000 nM
Estimate against measurement, compound 4: 1.6-fold (0.20 log units) above; the measured number falls inside the stated range.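

In this assay compound 4 is the only compound shown that gives a number rather than a limit, so acetyl in place of methyl, para to a large group, offers the one measured value in this set. The change amounts to an at least 1.3-fold lower number from compound 3 to compound 4 (0.11 log units; that floor lies within the scatter), so a real shift is not established. The comparison rests on a limit on one side, and most of the set gives no number: the limit of > 25000 nM in this assay, at which 3 of the 4 values shown sit.

Going by these compounds, how an amine or a carboxylic acid would read at this place stays open. So does whether a longer chain ending in a carbonyl would move the number further.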